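From 3-chlorophenyl to 4-bromophenyl on an amide nitrogen

This account rests on a few compounds, and the source may have more. Where it says the series, first, only, none or still open, it means among the compounds named here.

In a functional assay on NCI-H1299 cells (Homo sapiens) for inhibition, read by CCK-8 assay, with a stated time of 72 h, tested at 1 uM (a higher number here means more inhibition of growth at the concentration tested, a lower number less inhibition of growth), compound 1 `CN(C)C(=O)c1cc2cnc(Nc3ccc(NC(=O)C4(C(=O)Nc5ccc(Cl)cc5)CC4)cc3)nc2n1C1CCCC1` gives 52.2% and compound 2 `CN(C)C(=O)c1cc2cnc(Nc3ccc(NC(=O)C4(C(=O)Nc5cccc(O)c5)CC4)cc3)nc2n1C1CCCC1` gives 77.5% while compound 3 `CN(C)C(=O)c1cc2cnc(Nc3ccc(NC(=O)C4(C(=O)Nc5cccc(Cl)c5)CC4)cc3)nc2n1C1CCCC1` gives 47.9% under the same test. Compound 3 is thus level with compound 1 within the scatter and clearly under compound 2.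

Compound 4 `CN(C)C(=O)c1cc2cnc(Nc3ccc(NC(=O)C4(C(=O)Nc5ccc(Br)cc5)CC4)cc3)nc2n1C1CCCC1` awaits measurement. Its difference from compound 3 reads (4-bromophenyl in place of 3-chlorophenyl on an amide-type nitrogen). In short, compound 4 has 4-bromophenyl in place of 3-chlorophenyl on an amide-type nitrogen.

Going by the values given here, three measured steps bear on this. Putting 3-chlorophenyl in place of 4-chlorophenyl gave a number 4.3 percentage points lower from compound 1 to compound 3 (within the scatter) and so changed little. The larger steps both involve the hydroxy compound: one is a number 25.3 percentage points higher from compound 1 to compound 2 (beyond the scatter) and the other is a number 29.6 percentage points lower from compound 2 to compound 3 (beyond the scatter) with chloro in place of hydroxy. Compound 4 carries no hydroxy group. Among the compounds with values here, no measured pair compares bromo with chloro directly. The closest relative is compound 1 at 52.2% whose 4-chlorophenyl group differs from 4-bromophenyl only in the halogen.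

No step beyond the scatter is therefore expected in this assay for this change, only an estimated a number 2.1 percentage points higher from compound 3 to compound 4 (within the scatter) at most in size. Compound 4 is estimated at 50% with an expected range of 36% to 65% once measured.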

Compound 4, percent growth inhibition at one concentration: 27.6%
For compound 4 the middle estimate is 22.4 percentage points above the measured one; measured number outside the range, below it.
By their numbers in this assay, from the lowest: compound 4; then compounds 3 and 1 (each within the scatter of the next); then compound 2.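

In this assay the identity of the halogen on this phenyl group proves to matter: bromo in place of chloro on an aromatic carbon gave a number 24.6 percentage points lower from compound 1 to compound 4 (beyond the scatter) even though moving the chlorine had stayed within the scatter. The change from 3-chlorophenyl to 4-bromophenyl on the amide-type nitrogen gave a number 20.3 percentage points lower from compound 3 to compound 4 (beyond the scatter) and so was not the silent swap the two chlorophenyl compounds might suggest, while the hydroxy compound stands much further off, with a number 49.9 percentage points lower from compound 2 to compound 4 (beyond the scatter) and compound 4 lowest of all four at this single concentration. Nothing in the data shown accounts for this gap between two halogens on the same ring.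

Going by these compounds, whether the fall follows the size of the halogen or belongs to bromo alone remains open, and 4-fluorophenyl and 4-iodophenyl would extend that series, while 3-bromophenyl would show whether bromo behaves like chloro when moved around the ring. The lead held by the 3-hydroxyphenyl group also rests on one compound, so 3-aminophenyl or 3-methoxyphenyl would test how specific the hydroxy group is.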